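A few compounds are considered here, and "the series" means these few. Any claim that something is new, unique, unknown or untested is made for them only; others in the source may bear on it.

Measured so far:
- compound 1, `CCCCC(C(=O)OC)N1C(=O)/C(=C/c2ccc(C(=O)N[C@@H](CCCNC(=N)N)C(=O)N[C@@H](CCCCN)C(=O)N[C@@H](CCCC)C(N)=O)cc2)SC1=S`: 0.87 10^-6 cm/s
- compound 2, `CCCC[C@H](NC(=O)[C@H](CCCCN)NC(=O)[C@H](CCCNC(=N)N)NC(=O)c1ccc(/C=C2\NC(=S)N(c3ccccc3)C2=O)cc1)C(N)=O`: "impermeable" (no number reported) (no number reported)
- compound 3, `CCCC[C@H](NC(=O)[C@H](CCCCN)NC(=O)[C@H](CCCNC(=N)N)NC(=O)c1cccc(/C=C2\SC(=O)N(C3CCCC3)C2=O)c1)C(N)=O`: 1.9 10^-6 cm/s

Within the data shown here, in an ADME assay for permeability, using PAMPA (a lower number here means that the compound crosses the layer more slowly, a higher number that the compound crosses the layer faster), compound 1 gives 0.87 10^-6 cm/s, the lowest of the two numbers known; compound 3 sits a step above it that lies beyond the scatter, and compound 2 is reported only as "impermeable" (no number reported), without a number. Compound 4, `C=CCN1C(=O)/C(=C/c2ccc(C(=O)N[C@@H](CCCNC(=N)N)C(=O)N[C@@H](CCCCN)C(=O)N[C@@H](CCCC)C(N)=O)cc2)SC1=S`, has not yet been measured. It differs from compound 1 at one place: allyl in place of 1-(methoxycarbonyl)pentyl on an amide-type nitrogen in a ring. Among the measured compounds shown here, no measured pair covers a change of this kind, so the size of its effect in this assay cannot be read from the data; a small step, likely within the scatter and possibly downward, is expected. Compound 4 is therefore estimated at 0.7 10^-6 cm/s, range 0.3 10^-6 cm/s to 1.6 10^-6 cm/s, which would mean a step of a 1.2-fold lower number from compound 1 to compound 4 (0.09 log units; within the scatter).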

Compound 4, apparent permeability: 0.42 10^-6 cm/s
Compound 4: middle estimate off by 1.7-fold (0.22 log units), on the high side, and the stated range covers the measured number.
By their numbers in this assay, from the lowest: compound 4; then compound 1; then compound 3.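

In this assay, the substituent on the amide-type nitrogen in the ring proves able to move the read-out: allyl in place of 1-(methoxycarbonyl)pentyl gives a 2.1-fold lower number from compound 1 to compound 4 (0.32 log units; beyond the scatter). The swap removes 9 heavy atoms and 2 hydrogen-bond acceptors and brings in 3 heavy atoms, so a smaller group with no acceptors here does not give a higher number in this single pair. No available data explain this step.

Still open, going by these compounds, is whether the ester or the chain length carries the step. A plain pentyl chain or a carboxylic acid on this nitrogen would help separate the two.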